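Amine Tail Swap on the Shared Core: Thienopyridine to Methylpiperidine

This account rests on a few compounds, and the source may have more. Where it says the series, first, only, none or still open, it means among the compounds named here.

The series shares one core, seen in compound 1 `COc1cc2c(Oc3c(F)cc(NC(=O)NN4C(=O)CSC4c4c(F)cccc4F)cc3F)ccnc2cc1OCCCN1CCCC1`, which in a functional assay on MDA-MB-231 cells (Homo sapiens) for antiproliferative activity, read by MTT assay, with a stated time of 72 h (on this read-out lower numbers stand for stronger inhibition and higher numbers for weaker inhibition), gives 8350 nM. Compound 2 `COc1cc2c(Oc3c(F)cc(NC(=O)NN4C(=O)CSC4c4c(F)cccc4F)cc3F)ccnc2cc1OCCCN1CCc2sccc2C1` carries the same core with a different tail, and for compound 2 the result in this assay is "not determined" (no result reported), so it stands at no single number. Compound 3 `COc1cc2c(Oc3c(F)cc(NC(=O)NN4C(=O)CSC4c4c(F)cccc4F)cc3F)ccnc2cc1OCCCN1CCC(C)CC1` differs from compound 2 only at the tail: a group of 7 heavy atoms (6 carbon, 1 nitrogen; one six-membered non-aromatic ring with 1 hetero atom) in place of a group of 9 heavy atoms (7 carbon, 1 nitrogen, 1 sulfur; one five-membered aromatic ring with 1 hetero atom, one six-membered non-aromatic ring with 1 hetero atom), on a saturated chain carbon, three bonds along the chain from an oxygen on an aromatic ring. Going by the values given here, with no numeric value for compound 2, no step can be computed, and the only anchor is compound 1 at 8350 nM, whose tail is likewise a saturated amine ring on the same chain. The tail change from compound 2 to compound 3 is expected to move this assay by no more than the scatter, in no clear direction. Compound 3 is therefore estimated at 8000 nM, within a range of 3000 nM to 25000 nM.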

Compound 3, half-maximal inhibitory concentration: 3830 nM
Beside the measured number, compound 3's estimate is 2.1-fold (0.32 log units) above it; low and high end bracket the measured number.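

In this assay, the tail on the saturated chain carbon, three bonds along the chain from an oxygen on an aromatic ring, now has its first readable step: 4-methylpiperidin-1-yl in place of pyrrolidin-1-yl gives a 2.2-fold lower number from compound 1 to compound 3 (0.34 log units; beyond the scatter), a modest change that lies beyond the usual scatter. The step from compound 2 to compound 3 cannot be read, since compound 2 has no number, so the thienopyridine-type tail stays outside any comparison. No supporting data bear on what lies behind the step from the pyrrolidine to the methylpiperidine tail.

This single step changes ring size and adds a methyl group together, and a plain piperidin-1-yl tail would separate the two. On these data alone, whether a morpholin-4-yl ring or a longer chain carrying the same amine would move this assay further also remains open.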